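Ester to acid step on the dibromo core

The source may report more compounds than this note shows. Statements on the series, on what has been measured and on what is new or still open speak of the compounds shown alone.

Compound 1 `CCOC(=O)/C=C/c1cccc(OCc2nc(C)c(C)nc2C)c1` and compound 3 `Cc1nc(C)c(COc2cccc(/C=C/C(=O)O)c2)nc1C` share one core and differ in a single place: hydrogen in place of ethyl on an oxygen next to a carbonyl group. In a functional assay on a cell-free system (Platelet, plasma, Oryctolagus cuniculus) for inhibition, with a stated time of 5 min (on this read-out higher numbers stand for weaker inhibition and lower numbers for stronger inhibition), compound 1 gives 628000 nM. In this assay compound 3 gives 161000 nM. The step between them is a 3.9-fold lower number from compound 1 to compound 3 (0.59 log units; beyond the scatter), a step beyond the scatter but modest in size.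

Compound 2 `CCOC(=O)/C=C/c1cc(Br)c(OCc2nc(C)c(C)nc2C)c(Br)c1` is built on a second core; how the core of compound 2 differs from the core of compound 1 is not broken down here. In this assay compound 2 returns only a limit of the assay, > 2000000 nM. That value is the limit of > 2000000 nM in this assay, at which 1 of the 3 values shown sits, and not a measured number.

Compound 4 `Cc1nc(C)c(COc2c(Br)cc(/C=C/C(=O)O)cc2Br)nc1C` has not yet been measured in this assay. It differs from compound 2 as hydrogen in place of ethyl on an oxygen next to a carbonyl group. Among the compounds with values here, this is the same kind of change as from compound 1 to compound 3, and the place line reads the same word for word in both pairs, so the earlier step is the only guide. The step from compound 2 to compound 4 is expected to be an at least 1.3-fold lower number from compound 2 to compound 4 (0.12 log units; that floor lies within the scatter), beside the measured step of a 3.9-fold lower number from compound 1 to compound 3 (0.59 log units; beyond the scatter) on the first core. Because compound 2 stands at the limit of > 2000000 nM in this assay, at which 1 of the 3 values shown sits, the starting point is itself unknown, so the expected value for compound 4 remains wide and may again come back as a limit. Compound 4 is estimated at 1500000 nM in this assay, with a range from 400000 nM to 6000000 nM.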

Compound 4, half-maximal inhibitory concentration: 1290000 nM
Estimate against measurement, compound 4: 1.2-fold (0.07 log units) above; the range from low to high includes it.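

On the core of compound 2, in this assay, the change from ethoxycarbonyl to carboxy gives an at least 1.5-fold lower number from compound 2 to compound 4 (0.19 log units; that floor lies within the scatter), so the reading is only a floor and does not by itself establish a step beyond the usual scatter. The result fits a change that carries over from one core to the other in the same direction, but it does not show that the change has the same size on both cores, and two cores are too few to support a rule for the series: the same change on two cores in this assay, a 3.9-fold lower number (0.59 log units; beyond the scatter) from compound 1 to compound 3 and an at least 1.5-fold lower number (0.19 log units; that floor lies within the scatter) from compound 2 to compound 4; the limit leaves it open whether they differ. Going by these compounds, the true size of the step on the second core stays unknown, as its starting point, held by compound 2, is a limit of the assay and not a number: the limit of > 2000000 nM in this assay, at which 1 of the 4 values shown sits.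

On these data alone, what an amide or a hydroxamic acid in place of the carboxy group would give in this assay remains open, as does the effect of a longer chain in place of ethyl on the ester. Also open, as far as these compounds go, is whether chlorine in place of bromine would leave the ester-to-acid step on that core readable as a measured number at both ends.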